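Methoxy in Place of Methyl on Compound 1

This account rests on a few compounds, and the source may have more. Where it says the series, first, only, none or still open, it means among the compounds named here.

In a physicochemical assay for solubility, read by spectrophotometry, in phosphate buffer, measured as kinetic solubility, with a stated time of 18 h, at pH 7.4 (on this read-out higher numbers stand for higher solubility and lower numbers for lower solubility), compound 1 (`Cc1ccc(-c2nc3ccccc3s2)cc1NC(=O)c1cc([N+](=O)[O-])c(N2CCC(C(=O)O)CC2)cc1Cl`) gives 590 nM and compound 3 (`O=C(Nc1nc2ccc(F)cc2s1)c1cc([N+](=O)[O-])ccc1Cl`) gives 570 nM so the two lie within the scatter of each other at the top of the series. Compound 2 (`Cc1ccc(-c2nc3ccccc3s2)cc1NC(=O)c1cc([N+](=O)[O-])c(N(C)C)cc1Cl`) gives a much lower 30 nM in the same read-out. Compound 4 (`COc1ccc(-c2nc3ccccc3s2)cc1NC(=O)c1cc([N+](=O)[O-])c(N2CCC(C(=O)O)CC2)cc1Cl`) carries methoxy in place of methyl on an aromatic carbon, para to a 1,3-benzothiazol-2-yl group: methoxy in place of methyl on an aromatic carbon is the whole difference. Among the measured compounds shown here, the one measured step, a 20-fold lower number from compound 1 to compound 2 (1.29 log units; beyond the scatter) is large, but it replaces the 4-carboxypiperidin-1-yl group that compound 4 keeps. For the measured compounds named here, no measured step touches the methyl, so no change beyond the scatter is expected in this assay here. The expected step is a 1.2-fold lower number from compound 1 to compound 4 (0.07 log units; within the scatter) and nothing more. Compound 4 is estimated at 500 nM with an expected range from 180 nM to 1400 nM in this measurement.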

Compound 4, solubility: 210 nM
Compound 4: middle estimate off by 2.4-fold (0.38 log units), on the high side, and the stated range covers the measured number.
By their numbers in this assay, from the lowest: compound 2; then compound 4; then compounds 3 and 1 (each within the scatter of the next).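

In this assay, among the compounds shown here, methoxy in place of methyl, para to a 1,3-benzothiazol-2-yl group, gives a 2.8-fold lower number from compound 1 to compound 4 (0.45 log units; beyond the scatter), the first measured step at this position. The number therefore responds to this position as well as to the 4-carboxypiperidin-1-yl site, although this step is smaller than a 20-fold lower number from compound 1 to compound 2 (1.29 log units; beyond the scatter). Nothing available explains the step. The compounds shown leave open how hydroxyl, ethoxy or fluorine would read at this position. They also leave open whether methoxy would give a similar step with dimethylamino in the place of 4-carboxypiperidin-1-yl.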